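Nitro in Place of Iodo: What to Expect for Compound 4

The source may hold more compounds than are shown below. What is called first, only, known or untested is meant among the compounds shown, and "the series" means these compounds.

Compound 1, `C/C(=N/NC(=S)Nc1ccccc1I)c1ccccn1`: 4.1 nM
Compound 2, `C/C(=N/NC(=S)Nc1ccc(Cl)cc1)c1ccccn1`: 8.49 nM
Compound 3, `C/C(=N\NC(=S)Nc1cccc([N+](=O)[O-])c1)c1ccccn1`: 38 nM

All three were tested in a functional assay on MCF7 cells (Homo sapiens) for cytotoxicity, read by MTT assay, with a stated time of 48 h; on this read-out higher numbers stand for weaker inhibition and lower numbers for stronger inhibition. Compound 1 gives the lowest of the three numbers and so the strongest inhibition. Compound 2 comes nearest, yet its number already lies beyond the usual scatter of this assay, and compound 3 stands furthest away, with a clearly higher number.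

Compound 4, `C/C(=N/NC(=S)Nc1ccccc1[N+](=O)[O-])c1ccccn1`, has not yet been measured in this assay. It shares the core of compound 1 and differs at one place: nitro in place of iodo on an aromatic carbon.

Within the data shown here, no pair of measured compounds isolates this exact change. The closest pointer is compound 3, which also carries a nitro group on the same ring, though on a different aromatic carbon, and in this assay compound 3 gives 38 nM, well above compound 1. On that basis compound 4 is expected to inhibit more weakly than compound 1, with an expected step of a 3.7-fold higher number from compound 1 to compound 4 (0.56 log units; beyond the scatter) that goes beyond the scatter. In this assay compound 4 is estimated at 15 nM, within a range from 5 nM to 50 nM.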

Compound 4, half-maximal inhibitory concentration: 5.7 nM
Beside the measured number, compound 4's estimate is 2.6-fold (0.42 log units) above it; low and high end bracket the measured number.
By their numbers in this assay, from the lowest: compounds 1, 4 and 2 (each within the scatter of the next, the first and the last beyond it); then compound 3.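

In this assay, nitro in place of iodo on this aromatic carbon, ortho to a large group, gives a 1.4-fold higher number from compound 1 to compound 4 (0.14 log units; within the scatter), so the two compounds cannot be told apart on this read-out. This place therefore accepts a swap from one heavy atom to three, with hydrogen-bond acceptors entering where iodo had none, and the number stays within the scatter. No measurement on hand explains why these two groups read alike.

The compounds shown leave open how a smaller or quite different group, such as an amine or a carboxylic acid, would read on this same aromatic carbon. It also remains open whether iodo and nitro would read alike on the other carbons of this ring, as no pair shown isolates that comparison.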